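Amide series: nitro in place of trifluoromethyl on compound 2

The compounds below may be only part of what the source reports. "The series", "measured", "known", "first", "only" and "open" are said of these compounds alone.

Measured so far:
compound 1 `O=C(Nc1cccc([N+](=O)[O-])c1)Nc1nc2ccc(F)cc2s1`: 1.96 ug/mL
compound 2 `COc1cccc2sc(NC(=O)c3ccc(C(F)(F)F)cc3)nc12`: > 10 ug/mL

In a functional assay on SK-HEP1 cells (Homo sapiens) for antiproliferative activity, read by sulforhodamine B assay (on this read-out lower numbers stand for stronger inhibition of growth and higher numbers for weaker inhibition of growth), compound 1 gives 1.96 ug/mL. Compound 2 reaches only a limit in this assay, > 10 ug/mL, so its place among the numbers shown is the limit of > 10 ug/mL in this assay, at which 1 of the 2 values shown sits. Compound 3 `COc1cccc2sc(NC(=O)c3ccc([N+](=O)[O-])cc3)nc12` differs from compound 2 by nitro in place of trifluoromethyl on an aromatic carbon. Among the measured compounds shown here, no measured pair carries this change, so no step size is known. The step of a number no higher from compound 2 to compound 3 (the limit leaves the size open) is expected to be small, not clearly beyond the scatter. Compound 3 is therefore estimated at 10 ug/mL, in a range from 3 ug/mL to 30 ug/mL, with a limit again likely.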

Compound 3, concentration for 50% growth inhibition: > 10 ug/mL
Compound 3 gave a limit, no number (the forecaster's own chance of this, stated with the estimate: 60%); the middle value sits exactly at the limit.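

Compound 2 and compound 3 both end at a limit, so no step can be read for nitro in place of trifluoromethyl: the limit of > 10 ug/mL in this assay, at which 2 of the 3 values shown sit.

On these data alone, how far either compound lies past that limit, and whether this change alters growth inhibition at all, stays open.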